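Replacing the 2-hydroxypropyl chain with methyl

A few compounds are considered here, and "the series" means these few. Any claim that something is new, unique, unknown or untested is made for them only; others in the source may bear on it.

Measured in a functional assay on cells (Neutrophil, Homo sapiens) for inhibition, with a stated time of 10 min (a higher number here means a weaker inhibitor, a lower number a stronger inhibitor), so far:
compound 1 `CCOC(=O)c1cnn(CC(C)O)c1NC(=O)Nc1ccc(F)cc1` gives 0.2 nM
compound 2 `CCOC(=O)c1cnn(CC(C)O)c1NC(=O)NCc1ccccc1` gives 0.00054 nM
compound 3 `CCOC(=O)c1cnn(CC(O)CC)c1NC(=O)Nc1cccc2ccccc12` gives 9.6 nM

Compound 2 has the lowest number of the three, and its gaps to both others lie beyond the scatter. Compound 4 `CCOC(=O)c1cnn(C)c1NC(=O)NCc1ccccc1` differs from compound 2 in one place hydrogen in place of 1-hydroxyethyl on a saturated chain carbon bound to an aromatic nitrogen and the same difference reads as 2-hydroxypropyl to methyl.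

Among the compounds with values here, no measured step touches this chain. The only one, a 370-fold lower number from compound 1 to compound 2 (2.57 log units; beyond the scatter), sits on an amide-type nitrogen, so it shows only that a single change among these compounds can move the number far. Compound 3 carries another chain, but it also differs on the amide-type nitrogen, so it cannot isolate the effect of the chain.

Compound 2 stands at 0.00054 nM at the low extreme of this small set, so a substantial rise is more likely than a further fall, though the evidence is indirect. The expected change is a 37-fold higher number from compound 2 to compound 4 (1.57 log units; beyond the scatter) in this assay and it carries wide uncertainty. For compound 4 the estimated value is 0.02 nM with an expected range from 0.001 nM to 1 nM until it is measured.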

Compound 4, half-maximal inhibitory concentration: 1.3 nM
For compound 4 the middle estimate is 65-fold (1.81 log units) below the measured one, and the stated range ends below it.
By their numbers in this assay, from the lowest: compound 2; then compound 1; then compound 4; then compound 3.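

In this assay the change from 2-hydroxypropyl to methyl is a 2400-fold higher number from compound 2 to compound 4 (3.38 log units; beyond the scatter), so this chain, on a saturated chain carbon bound to an aromatic nitrogen, strongly affects the number when benzyl sits on the amide-type nitrogen. The step is larger in size than a 370-fold lower number from compound 1 to compound 2 (2.57 log units; beyond the scatter), which shows that this position can move the number at least as far as the amide-type nitrogen among the compounds shown. The step removes the carbons and the hydroxyl of 1-hydroxyethyl together, and no measurement given here explains its size.

As far as these compounds go, it remains open whether a plain propyl chain would keep the low number, or whether an amine or a carboxylic acid on the chain could stand in for the hydroxyl. Also open, from the compounds shown here alone, is whether the chain matters as much with the 4-fluorophenyl group of compound 1 on the amide-type nitrogen.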